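Working notes: bromo in place of methoxy

A few compounds are considered here, and "the series" means these few. Any claim that something is new, unique, unknown or untested is made for them only; others in the source may bear on it.

Measured so far in an ADME assay on CHO cells (Cricetulus griseus) for cytotoxicity, read by MTT assay (on this read-out higher numbers stand for weaker inhibition and lower numbers for stronger inhibition), are two compounds
- compound 1 `COc1ccc(C(=O)/C=C/c2ccc(CN3CCCCC3)c(O)c2)cc1` gives 197000 nM
- compound 2 `O=C(/C=C/c1ccc(O)c(CN2CCCCC2)c1)c1ccc(C(F)(F)F)cc1` gives 8220 nM

Compound 1 (197000 nM) holds the higher of the two numbers, so it is the weaker inhibitor on this read-out. Compound 2 (8220 nM) lies lower, and the gap between the two is beyond the scatter.

The next compound to be measured is compound 3 `O=C(/C=C/c1ccc(CN2CCCCC2)c(O)c1)c1ccc(Br)cc1`, which differs from compound 1 as follows: bromo in place of methoxy on an aromatic carbon, or 4-methoxyphenyl to 4-bromophenyl. For the measured compounds named here, no step between measured compounds informs this change, so the expectation is loose. Compound 2 (8220 nM) shows only that numbers well under that of compound 1 occur among these compounds. A move to a lower number is therefore expected, and the estimated step of a 6.6-fold lower number from compound 1 to compound 3 (0.82 log units; beyond the scatter) in this assay would lie beyond the scatter. The expected value for compound 3 is 30000 nM in this assay with an estimated range from 8000 nM to 120000 nM until the measurement is available.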

Compound 3, half-maximal inhibitory concentration: 7270 nM
Compound 3: the middle estimate sits 4.1-fold (0.62 log units) above what was measured, outside the stated range (below it).
By their numbers in this assay, from the lowest: compounds 3 and 2 (each within the scatter of the next); then compound 1.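

Exchanging methoxy for bromo on this aromatic carbon, para to a large group, gives a 27-fold lower number from compound 1 to compound 3 (1.43 log units; beyond the scatter) in this assay, so this position alone can move the cytotoxicity read-out by a large margin while the rest of the core of compound 1 stays unchanged. The earlier contrast between compound 1 and compound 2 involved more than one place and could not be assigned to any single change, whereas this step ties a large shift to the 4-methoxyphenyl to 4-bromophenyl exchange alone. Nothing at hand accounts for the size of this step.

With only methoxy and bromo compared directly at this position, a single pair cannot show which difference between the two groups matters, or whether the lower number is particular to bromo or shared by other replacements. Still open, going by these compounds, is how chloro, nitrile or an amine at the same position would read in this assay on the core of compound 3, and whether the step keeps its size when the rest of the core changes.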